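A few compounds are considered here, and "the series" means these few. Any claim that something is new, unique, unknown or untested is made for them only; others in the source may bear on it.

Compound 1, `Fc1cccc(C2=NCCCC2)c1`: in an assay on cell membranes for displacement of a labelled ligand from Neuronal acetylcholine receptor; alpha4/beta2 (Rattus norvegicus), read by radioligand binding, with a stated time of 30 min (a higher number here means a weaker inhibitor, a lower number a stronger inhibitor), compound 1 gives 2040 nM.
Compound 2, `Oc1cccc(C2=NCCCC2)c1`: in this assay compound 2 gives 32000 nM.

Of these two numbers, compound 2 has the higher one, and the step of a 16-fold higher number from compound 1 to compound 2 (1.20 log units; beyond the scatter) is large. Compound 3, `c1ccc(C2=NCCCC2)cc1`, is not yet measured; it differs from compound 2 by hydrogen in place of hydroxy on an aromatic carbon. Within the data shown here, the only measured step that bears on it is a 16-fold higher number from compound 1 to compound 2 (1.20 log units; beyond the scatter), which shows that the hydroxy-bearing compound 2 gave the weaker binding. On these data alone, removing the hydroxy is therefore expected to give a lower number in this assay, though whether it falls all the way back to the level of compound 1 is unknown. For compound 3 the expected step is a 6.4-fold lower number from compound 2 to compound 3 (0.81 log units; beyond the scatter). Compound 3 is estimated at 5000 nM, with a likely range from 1200 nM to 20000 nM.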

Compound 3, inhibition constant: 2080 nM
Estimate against measurement, compound 3: 2.4-fold (0.38 log units) above; the range from low to high includes it.
By their numbers in this assay, from the lowest: compounds 1 and 3 (each within the scatter of the next); then compound 2.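

Removing the hydroxy gives a 15-fold lower number from compound 2 to compound 3 (1.19 log units; beyond the scatter) in this assay and so ties the weak binding of compound 2 to the hydroxy itself, not to the loss of fluoro. With a 1.0-fold higher number from compound 1 to compound 3 (0.01 log units; within the scatter) as the other step, hydrogen and fluoro cannot be told apart at this position, so of the three groups only hydroxy shifts the number. Nothing measured here explains why the hydroxy has this effect.

On these data alone, whether a methoxy, an amine or a carboxylic acid at this place would behave like hydroxy or like hydrogen remains open. Also open, as far as these compounds go, is whether hydroxy on another carbon of the aromatic ring would cost as much.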